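A few compounds are considered here, and "the series" means these few. Any claim that something is new, unique, unknown or untested is made for them only; others in the source may bear on it.

Measured compounds in a functional assay on A549 cells (Homo sapiens) for cytotoxicity, with a stated time of 48 h; a lower number here means a stronger inhibitor, a higher number a weaker inhibitor:
Compound 1, `C[S+]([O-])/C=C/c1cc(=O)c2cc(C#N)ccc2o1`, gives only a limit of the assay, > 10000 nM.
Compound 2, `CCCC(=O)Oc1ccc2oc(/C=C/[S+](C)[O-])cc(=O)c2c1`, gives 2200 nM.
Compound 3, `CC(C)Oc1ccc2oc(/C=C/[S+](C)[O-])cc(=O)c2c1`, gives 1500 nM.

Compound 3 holds one of the two real numbers in this assay; its gap to compound 2, a 1.5-fold lower number from compound 2 to compound 3 (0.17 log units; within the scatter), lies within the scatter, so the two cannot be ranked. The third value, that of compound 1, is a limit only, (the limit of > 10000 nM in this assay, at which 1 of the 3 values shown sits).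

Compound 4, `CC(=O)Oc1ccc2oc(/C=C/[S+](C)[O-])cc(=O)c2c1`, differs from compound 3 by acetyl in place of isopropyl on an oxygen on an aromatic ring. The two steps from compound 1, an at least 4.5-fold lower number from compound 1 to compound 2 (0.65 log units; beyond the scatter) and an at least 6.6-fold lower number from compound 1 to compound 3 (0.82 log units; beyond the scatter), concern the cyano group and bear on this change only as a background. The step that resembles it most, a 1.5-fold lower number from compound 2 to compound 3 (0.17 log units; within the scatter), exchanges propylcarbonyl for isopropyl on the same oxygen and stayed within the scatter. A change from isopropyl to acetyl at the same place is therefore expected to give no step beyond the scatter in this assay. Compound 4 is estimated at 2000 nM, with a range from 900 nM to 4500 nM. This estimate means an expected step of a 1.3-fold higher number from compound 3 to compound 4 (0.12 log units; within the scatter).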

Compound 4, half-maximal inhibitory concentration: 4100 nM
Compound 4: the middle estimate sits 2.1-fold (0.31 log units) below what was measured; the measured number falls inside the stated range.
By their numbers in this assay, from the lowest: compounds 3, 2 and 4 (each within the scatter of the next, the first and the last beyond it). At a limit, above all of these: compound 1.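

Among these compounds, on the oxygen on the aromatic ring, the exchange of isopropyl for acetyl gives the first step at this place that lies beyond the scatter, a 2.7-fold higher number from compound 3 to compound 4 (0.44 log units; beyond the scatter), so the group on this oxygen can shift the number in this assay. This is no clean divide between the two kinds of group, however: compound 2 also carries an ester and stays within the scatter of compound 3, and a 1.9-fold higher number from compound 2 to compound 4 (0.27 log units; within the scatter) is within the scatter too, so the shorter acetyl cannot be told apart from propylcarbonyl. The remaining step, an at least 2.4-fold lower number from compound 1 to compound 4 (0.38 log units; beyond the scatter), rests on a limit of the assay, and no measurement at hand accounts for any of these steps.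

The compounds shown leave open how a free hydroxyl, a methoxy group or an amine would read at this place. They also leave open whether a longer acyl chain would stay within the scatter of compound 2.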